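A few compounds are considered here, and "the series" means these few. Any claim that something is new, unique, unknown or untested is made for them only; others in the source may bear on it.

Compound 3 `CC(=O)OCCO[C@H](CC=C(C)C)C1=CC(=O)c2c(O)ccc(O)c2C1=O` gives 15500 nM in a functional assay on DU-145 cells (Homo sapiens) for cytotoxicity, read by MTT assay (a lower number here means a stronger inhibitor, a higher number a weaker inhibitor), the lowest of the two numbers in the series; the nearest is compound 1 `CC(C)=CC[C@@H](OC(=O)CCO)C1=CC(=O)c2c(O)ccc(O)c2C1=O`, which in this assay gives 55300 nM. Compound 2 `CC(C)=CC[C@@H](OC(=O)c1ccco1)C1=CC(=O)c2c(O)ccc(O)c2C1=O` gives in this assay only a limit, > 100000 nM. Compound 4 `CC(C)=CC[C@@H](OC(=O)C1CCOC1)C1=CC(=O)c2c(O)ccc(O)c2C1=O` is not yet measured. It differs from compound 3 as follows: (oxolan-3-yl)carbonyl in place of 2-acetoxyethyl on an oxygen on a saturated carbon The ester at that oxygen is thus restored, as in compound 1 and compound 2. For the measured compounds named here, two measured steps bear on this change. Replacing the ester of compound 1 by the ether gave a 3.6-fold lower number from compound 1 to compound 3 (0.55 log units; beyond the scatter), and from the furan-2-yl ester of compound 2 the same change gave an at least 6.4-fold lower number from compound 2 to compound 3 (0.80 log units; beyond the scatter). Both point the same way: the 2-acetoxyethyl ether sits lower than either ester. Returning to an ester is therefore expected to give a higher number in this assay, of about the size seen in those steps, estimated as a 3.2-fold higher number from compound 3 to compound 4 (0.51 log units; beyond the scatter). For compound 4 the estimate in this assay is 50000 nM, with a range from 20000 nM to 150000 nM.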

Compound 4, half-maximal inhibitory concentration: 47500 nM
Compound 4: middle estimate off by 1.1-fold (0.02 log units), on the high side; measured number inside the range.
By their numbers in this assay, from the lowest: compound 3; then compounds 4 and 1 (each within the scatter of the next). At a limit, above all of these: compound 2.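

In this assay a further ester confirms the earlier direction (a 3.1-fold higher number from compound 3 to compound 4 (0.49 log units; beyond the scatter)), and the 2-acetoxyethyl ether of compound 3 stays lowest against all three esters shown. Among the esters, oxolan-3-yl and 2-hydroxyethyl on the carbonyl carbon cannot be told apart (a 1.2-fold lower number from compound 1 to compound 4 (0.07 log units; within the scatter)), so a five-membered non-aromatic ring and an open hydroxy chain read alike here. Compound 2 gives only a limit, and the step to the oxolan-3-yl ester (an at least 2.1-fold lower number from compound 2 to compound 4 (0.32 log units; beyond the scatter)) is therefore a floor, showing that the esters do not all sit together: the limit of > 100000 nM in this assay, at which 1 of the 4 values shown sits.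

Going by these compounds, each ether-to-ester step changes the linkage and the group together, so the share of the ether oxygen itself stays open. Also open, on these data alone, is how an amine or a carboxylic acid on the ester, or a longer chain on the ether, would read in this assay at this oxygen.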